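Swapping ethyl for ethoxy on the carbonyl of compound 2

This account rests on a few compounds, and the source may have more. Where it says the series, first, only, none or still open, it means among the compounds named here.

Compound 1, `CCC(=O)Nc1ccc(Nc2cccc(OC)c2)cc1`: 1.8 nM
Compound 2, `CCC(=O)Nc1ccc(N(C)c2cccc(OC)c2)cc1`: 0.17 nM

Both compounds were measured in an assay on isolated protein for binding affinity to melatonin receptor type 1B (Homo sapiens); on this read-out lower numbers stand for stronger inhibition and higher numbers for weaker inhibition. Among the measured compounds shown here, compound 2 holds the lowest of the two numbers; the only step measured so far, an 11-fold lower number from compound 1 to compound 2 (1.02 log units; beyond the scatter), is what separates it from compound 1, and that step is large.

Compound 3, `CCOC(=O)Nc1ccc(N(C)c2cccc(OC)c2)cc1`, has not yet been measured. It differs from compound 2 in one place: ethoxy in place of ethyl on a carbonyl carbon. The carbonyl carbon keeps its amide-type nitrogen neighbour, so the propanoylamino group becomes an (ethoxycarbonyl)amino group.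

For the measured compounds named here, no measured step touches this part of the molecule. Going by the values given here, the single step in hand, an 11-fold lower number from compound 1 to compound 2 (1.02 log units; beyond the scatter), concerns a methyl on a nitrogen and gives no guide for the carbonyl side, so the size of the coming step cannot be read from the data. In the absence of such a guide, the expectation for compound 3 is a modest move toward a higher number, a 2.9-fold higher number from compound 2 to compound 3 (0.47 log units; beyond the scatter), though a result within the scatter of compound 2 would not surprise. The estimate for compound 3 in this assay is 0.5 nM, with a range from 0.1 nM to 2.5 nM.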

Compound 3, inhibition constant: 7.2 nM
The estimate for compound 3 lay 14-fold (1.16 log units) below the measured number; measured number above the stated range.
By their numbers in this assay, from the lowest: compound 2; then compound 1; then compound 3.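

In this assay, the carbonyl side of the molecule turns out to be highly sensitive to a small edit: putting ethoxy in place of ethyl on the carbonyl carbon, which turns propanoylamino into (ethoxycarbonyl)amino, gives a 42-fold higher number from compound 2 to compound 3 (1.63 log units; beyond the scatter), a large step beyond the usual scatter. The earlier step on the nitrogen, an 11-fold lower number from compound 1 to compound 2 (1.02 log units; beyond the scatter), went toward stronger inhibition, whereas this one shows that a single change can also move the number a long way toward weaker inhibition, even though the entering group differs from the leaving one by only a single oxygen atom. Nothing available explains the size of this shift, so it can be recorded but not attributed to any property of the ethoxy group.

With only ethyl and ethoxy compared on this carbonyl carbon, the compounds shown leave open whether the oxygen itself or the ethoxy group as a whole drives the change. A methylamino group, a methoxy group or a longer chain such as propoxy in the same place could help separate these possibilities, and the same swap on compound 1 could show whether the step holds when the nitrogen carries hydrogen instead of methyl.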